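From 2-methylphenyl to 3,5-dimethylphenyl, under a limit

The source may hold more compounds than are shown below. What is called first, only, known or untested is meant among the compounds shown, and "the series" means these compounds.

- compound 1 `COC1=C(C)C(=O)/C(=C(O)/C=C/c2ccc(Br)cc2)C(=O)C1(C)C`: < 4 ug/mL
- compound 2 `COC1=C(C)C(=O)/C(=C(O)/C=C/c2ccc(OC)cc2)C(=O)C1(C)C`: < 4 ug/mL
- compound 3 `COC1=C(C)C(=O)/C(=C(O)/C=C/c2ccccc2C)C(=O)C1(C)C`: < 4 ug/mL

These results come from a functional assay on HUVEC cells (Homo sapiens) (on this read-out higher numbers stand for an effect only at larger amounts of compound and lower numbers for an effect already at smaller amounts), and each one is a limit, not a number. Compound 3 therefore stands only at a limit of < 4 ug/mL. The same is true across the series: the limit of < 4 ug/mL in this assay, at which 3 of the 3 values shown sit.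

Compound 4 `COC1=C(C)C(=O)/C(=C(O)/C=C/c2cc(C)cc(C)c2)C(=O)C1(C)C` differs from it by one change: 3,5-dimethylphenyl in place of 2-methylphenyl on a double-bonded chain carbon bound to a double-bonded chain carbon. Here 3,5-dimethylphenyl stands in place of 2-methylphenyl.

The closest evidence comes from two other changes at that place: a step that the two limits leave unreadable from compound 1 to compound 3 and a step that the two limits leave unreadable from compound 2 to compound 3. Neither gives a size or a direction, so no real shift can be predicted.

The expected change is a step that the limit leaves unreadable from compound 3 to compound 4. Compound 4 is estimated at 2 ug/mL, within an expected range of 0.5 ug/mL to 5 ug/mL.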

Compound 4, concentration for half-maximal effect: < 4 ug/mL
Compound 4 gave a limit, no number (the forecaster's own chance of this, stated with the estimate: 75%); the middle value lies beyond the limit too.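

No step between compound 4 and compound 1, compound 2 or compound 3 can be read in this assay, since each result is only a limit: the limit of < 4 ug/mL in this assay, at which 4 of the 4 values shown sit.

Going by these compounds, whether changing the aromatic group on the chain shifts the effect at all, and in which direction, stays open.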